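A Thiophene in Place of a Phenyl on the Sulfonyl

A few compounds are considered here, and "the series" means these few. Any claim that something is new, unique, unknown or untested is made for them only; others in the source may bear on it.

Three compounds share one core, and only compound 3 `COc1ccc(-c2cc(=O)c3c(OC)cc(OC)cc3n2S(=O)(=O)c2ccc(Br)cc2)cc1` gives a number: in a functional assay on SUP-B15 cells (Homo sapiens) for antiproliferative activity, with a stated time of 72 h (a lower number here means that less compound is needed, a higher number that more compound is needed for the effect), compound 3 gives 63800 nM. Compound 1 `COc1ccc(-c2cc(=O)c3c(OC)cc(OC)cc3n2S(=O)(=O)c2ccc(C)c([N+](=O)[O-])c2)cc1` reaches only a limit of the assay, > 51700 nM. Compound 2 `COc1ccc(-c2cc(=O)c3c(OC)cc(OC)cc3n2S(=O)(=O)c2ccc(F)cc2)cc1` likewise stops at a limit, > 65500 nM. The steps from compound 1 are therefore not readable: a step that the two limits leave unreadable from compound 1 to compound 2 and a step that the limit leaves unreadable from compound 1 to compound 3. For the measured compounds named here, the one readable step, an at least 1.0-fold lower number from compound 2 to compound 3 (0.01 log units; that floor lies within the scatter), lies within the scatter.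

Compound 4 `COc1ccc(-c2cc(=O)c3c(OC)cc(OC)cc3n2S(=O)(=O)c2ccc(Br)s2)cc1` is not yet measured. It differs from compound 3 by 5-bromothiophen-2-yl in place of 4-bromophenyl on a sulfonyl sulfur. Going by the values given here, no measured step exchanges a six-membered ring for a five-membered one on the sulfonyl sulfur; the only step at that position, from compound 2 to compound 3, was within the scatter, and the other two sulfonyl variants reach only limits. The chemist therefore expects no step beyond the scatter for compound 4, a 1.1-fold lower number from compound 3 to compound 4 (0.03 log units; within the scatter). Two of the three values shown are limits, and a reported limit for compound 4 would not surprise. The estimate for compound 4 is 60000 nM, in a range from 20000 nM to 200000 nM.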

Compound 4, half-maximal effective concentration: > 48200 nM
Compound 4: a limit, no number; the forecaster's own chance of this, stated with the estimate: 50%; the middle value is on the limit's open side.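

In this assay compound 4 stops at a limit, > 48200 nM, not a number, so its steps to compound 1, compound 2 and compound 3 cannot be read. The compounds shown leave open whether the 5-bromothiophen-2-yl group differs from 4-bromophenyl in this read-out at all.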